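Swapping Trifluoromethyl for Methoxy on an Inactive Pair

The source may report more compounds than this note shows. Statements on the series, on what has been measured and on what is new or still open speak of the compounds shown alone.

Of the compounds shown here, two have been tested in an ADME assay on HaCaT cells (Homo sapiens) for antiproliferative activity, read by MTT assay, with a stated time of 48 h; a lower number here means a stronger inhibitor, a higher number a weaker inhibitor. Compound 1 `O=C(/C=C\Nc1ccc(F)cc1)c1cn(-c2ccccc2)nc1-c1ccc(F)cc1` gives > 50000 nM, which is a limit of the assay rather than a number. Compound 2 `O=C(/C=C\Nc1ccc(C(F)(F)F)cc1)c1cn(-c2ccccc2)nc1-c1ccc(F)cc1` gives > 50000 nM, likewise a limit. The step that the two limits leave unreadable from compound 1 to compound 2 is therefore unreadable. Both shown values sit at the limit of > 50000 nM in this assay, at which 2 of the 2 values shown sit, so compound 2 stands at the edge of what the assay can report, with no number of its own.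

Compound 3 `COc1ccc(N/C=C\C(=O)c2cn(-c3ccccc3)nc2-c2ccc(F)cc2)cc1` differs from compound 2 by methoxy in place of trifluoromethyl on an aromatic carbon. Within the data shown here, no measured step bears on this change, because the only step available is a step that the two limits leave unreadable from compound 1 to compound 2, which has no readable size. With nothing pointing either way, the step from compound 2 to compound 3 is estimated as a step that the limit leaves unreadable from compound 2 to compound 3, that is, no shift expected beyond the scatter. Compound 3 is expected at 60000 nM, with a range from 20000 nM to 200000 nM, and most likely it will again be reported only as a limit.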

Compound 3, half-maximal inhibitory concentration: 19600 nM
Compound 3: middle estimate off by 3.1-fold (0.49 log units), on the high side, outside the stated range (below it).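

Compound 3 is the only one of the three with a real number in this assay, so the group at this place, para to a large group, can move the read-out after all. Methoxy in place of trifluoromethyl gives an at least 2.5-fold lower number from compound 2 to compound 3 (0.40 log units; beyond the scatter), and methoxy in place of fluoro gives an at least 2.5-fold lower number from compound 1 to compound 3 (0.40 log units; beyond the scatter). Both sizes are only lower bounds, because compound 1 and compound 2 each carry a limit rather than a number: the limit of > 50000 nM in this assay, at which 2 of the 3 values shown sit.

On these data alone, the step between compound 1 and compound 2 cannot be read, so how fluoro and trifluoromethyl compare here stays unknown. As far as these compounds go, it also stays open whether the oxygen of methoxy matters, and whether a hydroxyl, an amine or a longer chain such as ethoxy at this place would lower the number further.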